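Thiophene for Tolyl on the Sulfonamide of Compound 3

This account rests on a few compounds, and the source may have more. Where it says the series, first, only, none or still open, it means among the compounds named here.

In a functional assay on SiHa cells (Homo sapiens) for cytotoxicity, read by MTT assay, with a stated time of 48 h (on this read-out lower numbers stand for stronger inhibition and higher numbers for weaker inhibition), compound 1 `CCCCCCCCCCCCNC(=O)[C@@H](NC(=O)c1ccccc1)[C@@H](C)O` gives 63900 nM. Compound 2 `CCCCCCCCCCCCNC(=O)[C@@H](NC(=O)c1cccs1)[C@@H](C)O` gives 23900 nM. Compound 3 `CCCCCCCCCCCCNC(=O)[C@@H](NS(=O)(=O)c1ccc(C)cc1)[C@@H](C)O` gives 31600 nM, the second highest of the three numbers; the step of a 2.0-fold lower number from compound 1 to compound 3 (0.31 log units; beyond the scatter) lies beyond the scatter, whereas the step of a 1.3-fold higher number from compound 2 to compound 3 (0.12 log units; within the scatter) lies within it. Compound 4 `CCCCCCCCCCCCNC(=O)[C@@H](NS(=O)(=O)c1cccs1)[C@@H](C)O` differs from compound 3 by thiophen-2-yl in place of 4-methylphenyl on a sulfonyl sulfur. The closest measured step is a 2.7-fold lower number from compound 1 to compound 2 (0.43 log units; beyond the scatter), the same exchange made on a carbonyl carbon. Carried over to the sulfonyl sulfur, a modest lowering of the number in this assay is expected for compound 4, about a 2.0-fold lower number from compound 3 to compound 4 (0.30 log units; within the scatter). Compound 4 is therefore estimated at 16000 nM, with a range of 7000 nM to 40000 nM.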

Compound 4, half-maximal inhibitory concentration: 30900 nM
For compound 4 the middle estimate is 1.9-fold (0.29 log units) below the measured one; low and high end bracket the measured number.
By their numbers in this assay, from the lowest: compounds 2, 4 and 3 (each within the scatter of the next); then compound 1.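

On the sulfonyl sulfur, thiophen-2-yl in place of 4-methylphenyl gives in this assay only a 1.0-fold lower number from compound 3 to compound 4 (0.01 log units; within the scatter) and so does not repeat a 2.7-fold lower number from compound 1 to compound 2 (0.43 log units; beyond the scatter) on a carbonyl carbon. With thiophen-2-yl kept, sulfonyl for carbonyl gives a 1.3-fold higher number from compound 2 to compound 4 (0.11 log units; within the scatter) while the change from benzoyl to (thiophen-2-yl)sulfonyl gives a 2.1-fold lower number from compound 1 to compound 4 (0.32 log units; beyond the scatter) and thus leaves compound 1 apart from compound 4. No measurement shown here accounts for this difference between the two positions.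

The compounds shown leave open how a plain phenyl on the sulfonyl sulfur would compare with compound 3 and compound 4. They also leave open whether an amine or a carboxylic acid on the thiophene ring would move the number beyond the scatter.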